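Furan-2-yl to pyridin-3-yl in the aryl pyridine series

A few compounds are considered here, and "the series" means these few. Any claim that something is new, unique, unknown or untested is made for them only; others in the source may bear on it.

Values so far in a functional assay on HeLa cells (Homo sapiens) for cytotoxicity, read by ELISA, with a stated time of 2 days; on this read-out higher numbers stand for weaker inhibition and lower numbers for stronger inhibition:
- compound 1 (`Oc1ccccc1-c1cc(-c2ccccc2)nc(-c2ccco2)c1`) gives 9700 nM
- compound 2 (`Oc1cccc(-c2cc(-c3ccccc3)nc(-c3cccs3)c2)c1`) gives 15300 nM
- compound 3 (`Oc1cccc(-c2cc(-c3ccccc3)nc(-c3ccco3)c2)c1`) gives 10900 nM

Compound 3 stands inside the span of these three numbers, and neither of its steps separates it from the others (a 1.1-fold higher number from compound 1 to compound 3 (0.05 log units; within the scatter); a 1.4-fold lower number from compound 2 to compound 3 (0.15 log units; within the scatter)).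

Compound 4 (`Oc1cccc(-c2cc(-c3ccccc3)nc(-c3cccnc3)c2)c1`) has pyridin-3-yl in place of furan-2-yl on an aromatic carbon. The closest evidence is the exchange of thiophen-2-yl for furan-2-yl at this same place (a 1.4-fold lower number from compound 2 to compound 3 (0.15 log units; within the scatter)). The move to 3-hydroxyphenyl from 2-hydroxyphenyl elsewhere on the core was equally small (a 1.1-fold higher number from compound 1 to compound 3 (0.05 log units; within the scatter)). Among the compounds with values here, no six-membered ring has yet been measured at this place, so the range stays wide.

No step beyond the scatter is expected in this assay, and no firm direction either (a 1.2-fold higher number from compound 3 to compound 4 (0.08 log units; within the scatter)). The estimated value for compound 4 is 13000 nM (expected range 5500 nM to 30000 nM).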

Compound 4, half-maximal inhibitory concentration: 17500 nM
For compound 4 the middle estimate is 1.3-fold (0.13 log units) below the measured one; measured number inside the range.
By their numbers in this assay, from the lowest: compounds 1, 3, 2 and 4 (each within the scatter of the next).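

In this assay, the first six-membered aromatic ring at this place, pyridin-3-yl, gives no step beyond the scatter from the furan-2-yl of compound 3 (a 1.6-fold higher number from compound 3 to compound 4 (0.21 log units; within the scatter)) or the thiophen-2-yl of compound 2 (a 1.1-fold higher number from compound 2 to compound 4 (0.06 log units; within the scatter)). These three aromatic rings, on the carbon next to the ring nitrogen of the shared core, therefore cannot be told apart in this assay, and the change from a five-membered to a six-membered ring does not separate them. Nothing available explains this flat result.

Going by these compounds, it remains open whether this place responds to anything other than a single aromatic ring bearing one hetero atom, such as a plain phenyl, a morpholine, a primary amine, a carboxylic acid or a longer alkyl chain. Substituents on the pyridin-3-yl ring also remain open.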